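This account rests on a few compounds, and the source may have more. Where it says the series, first, only, none or still open, it means among the compounds named here.

Measured so far:
compound 1 `O=C(Nc1cccc(-n2cc(-c3ccncc3)c(-c3cc(O)cc(Cl)c3)n2)c1)Nc1ccc(Cl)c(Cl)c1` with 94% in a functional assay on A498 cells (Homo sapiens) for inhibition, read by sulforhodamine B assay, with a stated time of 48 h, tested at 0.1 uM; a higher number here means a weaker effect of the compound at the concentration tested, a lower number a stronger effect;
compound 2 `COc1cc(Cl)cc(-c2nn(-c3cccc(NC(=O)Nc4ccc(Cl)c(Cl)c4)c3)cc2-c2ccncc2)c1` with 58% in this assay.

Compound 2 stands lowest of the two numbers, the nearest being compound 1, separated by a number 36 percentage points lower from compound 1 to compound 2 (beyond the scatter). Compound 3 is `COc1cc(Cl)cc(-c2nn(-c3cccc(NC(=O)c4cccc(C(F)(F)F)c4)c3)cc2-c2ccncc2)c1`. It differs from compound 2 by 3-(trifluoromethyl)phenyl in place of (3,4-dichlorophenyl)amino on a carbonyl carbon. Going by the values given here, that single measured step concerns an oxygen on an aromatic ring, a different place from the carbonyl carbon changed here, so no measured step bears on this change. The size and direction of the step in this assay for compound 3 are therefore undetermined, and a step of a number 4 percentage points higher from compound 2 to compound 3 (within the scatter) is expected only as a neutral guess. Compound 3 is estimated at 62%, between 30% and 95%.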

Compound 3, a percentage reported as activity, at one concentration (the size of the read-out at that concentration, not a potency): 52%
Compound 3: the middle estimate sits 10 percentage points above what was measured; the measured number falls inside the stated range.
By their numbers in this assay, from the lowest: compounds 3 and 2 (each within the scatter of the next); then compound 1.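

Putting 3-(trifluoromethyl)phenyl in place of (3,4-dichlorophenyl)amino on the carbonyl carbon gives a number 6 percentage points lower from compound 2 to compound 3 (within the scatter) in this assay. This position therefore accepts a swap of the whole aryl-bearing group, including loss of the hydrogen-bond donor counted on the leaving group, without a change beyond the scatter in this pair. No available evidence explains this outcome.

On these data alone, it remains open whether a much smaller group on this carbonyl carbon, such as methyl or morpholine, would keep the read-out. Also open, as far as these compounds go, is whether exchanging methoxy for hydroxy has the same effect when 3-(trifluoromethyl)phenyl is present.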